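From 2-bromophenyl to 4-bromophenyl on a shared core

A few compounds are considered here, and "the series" means these few. Any claim that something is new, unique, unknown or untested is made for them only; others in the source may bear on it.

Values in a functional assay on HepG2 cells (Mus musculus) for antiproliferative activity against HepG2 (Homo sapiens), read by MTT assay, with a stated time of 48 h (on this read-out lower numbers stand for stronger inhibition and higher numbers for weaker inhibition), follow
- Compound 1 `COc1cccc(C(=O)Nc2nnc(/C=C/c3cc(OC)c(OC)c(OC)c3Br)s2)c1` gives 120 nM
- Compound 2 `COc1ccc(C(=O)Nc2nnc(/C=C/c3cc(OC)c(OC)c(OC)c3Br)s2)cc1` gives 220 nM
- Compound 3 `COc1cc(/C=C/c2nnc(NC(=O)c3ccccc3Br)s2)c(Br)c(OC)c1OC` gives 250 nM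

Compound 3 stands level with compound 2 within the scatter, and apart from compound 1 by a modest margin (a 2.1-fold higher number from compound 1 to compound 3 (0.32 log units; beyond the scatter)). Compound 4 `COc1cc(/C=C/c2nnc(NC(=O)c3ccc(Br)cc3)s2)c(Br)c(OC)c1OC` carries 4-bromophenyl in place of 2-bromophenyl on a carbonyl carbon. The other measured changes at that carbonyl carbon were small (a 1.8-fold higher number from compound 1 to compound 2 (0.26 log units; within the scatter) and a 1.1-fold higher number from compound 2 to compound 3 (0.06 log units; within the scatter)), and none directly tests moving the bromine. No step beyond the scatter is therefore expected in this assay for this change. The expected step is small (a 1.3-fold lower number from compound 3 to compound 4 (0.10 log units; within the scatter)). For compound 4 the estimated value is 200 nM (expected range 90 nM to 450 nM).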

Compound 4, half-maximal inhibitory concentration: 200 nM
Beside the measured number, compound 4's estimate shows no gap at the digits printed; the range from low to high includes it.
By their numbers in this assay, from the lowest: compounds 1, 4, 2 and 3 (each within the scatter of the next, the first and the last beyond it).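

In this assay, among the compounds shown here, 4-bromophenyl in place of 2-bromophenyl on the carbonyl carbon (a 1.3-fold lower number from compound 3 to compound 4 (0.10 log units; within the scatter)) is the first direct test of the bromine's place on this ring, and it finds no difference beyond the scatter. Bromo in place of methoxy on an aromatic carbon (a 1.1-fold lower number from compound 2 to compound 4 (0.04 log units; within the scatter)) and 4-bromophenyl in place of 3-methoxyphenyl (a 1.7-fold higher number from compound 1 to compound 4 (0.22 log units; within the scatter)) leave compound 4 level with compound 2 and compound 1, whereas compound 3 stood apart from compound 1. Nothing available accounts for this result.

Still open, going by these compounds, is how an amine or a carboxylic acid in place of the bromophenyl on this carbonyl carbon would read in this assay.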